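The source may report more compounds than this note shows. Statements on the series, on what has been measured and on what is new or still open speak of the compounds shown alone.

Measured compounds:
compound 1 `CC(=O)OCc1cc(N)c(Nc2ccc(C#N)cc2)cc1Oc1c(C)cc(C#N)cc1C` gives 16.7 ug/mL in a physicochemical assay for solubility, read by HPLC, at pH 2; on this read-out higher numbers stand for higher solubility and lower numbers for lower solubility
compound 2 `COCc1cc(N)c(Nc2ccc(C#N)cc2)cc1Oc1c(C)cc(/C=C/C#N)cc1C` gives 1.7 ug/mL in this assay

Among the measured compounds shown here, compound 2 stands as the lower of the two numbers; compound 1 is higher, and that gap lies beyond the scatter, though the two compounds differ in more than one place, so no single step connects them. Compound 3 `CC(=O)OCc1cc(N)c(Nc2ccc(C#N)cc2)cc1Oc1c(C)cc(/C=C/C#N)cc1C` differs from compound 2 by acetyl in place of methyl on an oxygen on a saturated carbon. For the measured compounds named here, no step of this kind has been measured here. A small rise is expected, within or near the scatter, with the step from compound 2 to compound 3 estimated at a 1.8-fold higher number from compound 2 to compound 3 (0.25 log units; within the scatter). Compound 3 is expected to give about 3 ug/mL in this assay, with a range from 1 ug/mL to 10 ug/mL.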

Compound 3, solubility: 1.87 ug/mL
For compound 3 the middle estimate is 1.6-fold (0.21 log units) above the measured one; the measured number falls inside the stated range.
By their numbers in this assay, from the lowest: compounds 2 and 3 (each within the scatter of the next); then compound 1.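

In this assay, acetyl in place of methyl on an oxygen on a saturated carbon gives a 1.1-fold higher number from compound 2 to compound 3 (0.04 log units; within the scatter), so with 2-cyanoethenyl present, methoxymethyl and acetoxymethyl cannot be told apart. Among the compounds shown here, the one step beyond the scatter lies on the aromatic carbon, where 2-cyanoethenyl in place of cyano gives an 8.9-fold lower number from compound 1 to compound 3 (0.95 log units; beyond the scatter). No measurement here accounts for either step. On these data alone, it remains open whether methoxymethyl and acetoxymethyl would also read alike with cyano on the aromatic carbon. Also open, as far as these compounds go, is how an amine or a carboxylic acid in either place would read in this assay.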